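Adding a Second Methoxy Group: What the Data Suggest

The source may hold more compounds than are shown below. What is called first, only, known or untested is meant among the compounds shown, and "the series" means these compounds.

Of the compounds shown here, three have been measured in a functional assay on the whole organism (Cricetulus griseus) with Cricetinae gen. sp. as the target; a lower number here means that less compound is needed, a higher number that more compound is needed for the effect. Compound 1 `COc1cccc(-c2n[nH]c(-c3ccccc3C)n2)c1` gives 0.08 mg/kg. Compound 2 `CCc1ccccc1-c1n[nH]c(-c2cccc(OC)c2)n1` gives 0.04 mg/kg. Compound 3 `COc1cccc(-c2n[nH]c(-c3cc(OC)ccc3C)n2)c1` gives 1 mg/kg. The values of compound 1 and compound 2 lie within the usual scatter of each other. Compound 3 differs from compound 1 in one place, (methoxy in place of hydrogen on an aromatic carbon), and that change made the step of a 13-fold higher number from compound 1 to compound 3 (1.10 log units; beyond the scatter). The difference between the cores of compound 1 and compound 2 is not broken down here.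

Compound 4 `CCc1ccccc1-c1n[nH]c(-c2cc(OC)cc(OC)c2)n1` has not yet been measured. It differs from compound 2 by methoxy in place of hydrogen on an aromatic carbon. Going by the values given here, this is the same kind of change as the one from compound 1 to compound 3, but not the same change: in compound 3 the added methoxy sits para to a methyl group, whereas in compound 4 it sits meta to a methoxy group. Among the compounds with values here, the step from compound 2 to compound 4 in this assay is expected to be a 10-fold higher number from compound 2 to compound 4 (1.00 log units; beyond the scatter), because the only measured example of this kind of change is a 13-fold higher number from compound 1 to compound 3 (1.10 log units; beyond the scatter). Compound 4 is therefore estimated at 0.4 mg/kg, with a range from 0.1 mg/kg to 1.6 mg/kg.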

Compound 4, dose for half-maximal effect: 10 mg/kg
For compound 4 the middle estimate is 25-fold (1.40 log units) below the measured one; measured number outside the range, above it.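

In this assay, putting methoxy in place of hydrogen on an aromatic carbon gives a 250-fold higher number from compound 2 to compound 4 (2.40 log units; beyond the scatter), so the change pushes the number up on this core as well. The direction of the change is shared by both cores in these two examples, but its size does not carry over from one core to the other: the same change on two cores in this assay, a 13-fold higher number (1.10 log units; beyond the scatter) from compound 1 to compound 3 and a 250-fold higher number (2.40 log units; beyond the scatter) from compound 2 to compound 4, 20-fold (1.30 log units) apart, beyond the scatter of two such steps. Going by these compounds alone, this does not show what sets the size of the step: there are only two examples, the added methoxy stands in a different place in each, and in compound 4 it sits meta to a methoxy group, so the effect of the core cannot be separated from the effect of the place.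

The compounds shown leave open how the core of compound 1 would respond to a methoxy in the place it takes in compound 4, which would help to separate core from place. They also leave open whether a smaller group such as fluorine or hydroxyl, or a longer chain such as ethoxy, would raise the number as steeply as methoxy does.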